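The source may report more compounds than this note shows. Statements on the series, on what has been measured and on what is new or still open speak of the compounds shown alone.

Three compounds have been measured in a functional assay on MCF7 cells (Homo sapiens) for inhibition, read by CCK-8 assay, with a stated time of 48 h; a lower number here means a stronger inhibitor, a higher number a weaker inhibitor:

Compound 1 `Cc1ccc(NC(=S)NC(=O)c2cn(-c3ccccc3)nc2-c2ccc(Cl)cc2)cc1` gives 5980 nM.
Compound 2 `O=C(NC(=S)Nc1ccc(F)cc1)c1cn(-c2ccccc2)nc1-c1ccccc1` gives 6820 nM.
Compound 3 `COc1ccc(NC(=S)NC(=O)c2cn(-c3ccccc3)nc2-c2ccc(OC)cc2)cc1` gives 4210 nM.

All three share the same core and differ only in the groups on their two outer aromatic rings. In this assay compound 1 sits with compound 2 as its nearest neighbour and compound 3 as its furthest, yet neither gap reaches beyond the usual scatter of repeated measurements, so the three numbers cannot be told apart with confidence.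

Compound 4 `Cc1ccc(NC(=S)NC(=O)c2cn(-c3ccccc3)nc2-c2ccc(C)cc2)cc1` has not yet been measured. It differs from compound 1 in one place: methyl in place of chloro on an aromatic carbon. The group that leaves and the group that enters are each a single heavy atom, sit on the same aromatic carbon, and neither adds nor removes a hydrogen-bond donor or acceptor.

Within the data shown here, no measured pair here shows this exact change, so the expectation rests on how little the three measured compounds differ from one another. A step of this kind is expected to stay within the scatter in this assay, in no firm direction, so that the step of a 1.1-fold lower number from compound 1 to compound 4 (0.04 log units; within the scatter) is estimated to be small. Compound 4 is therefore expected to give about 5500 nM, with a likely range from 2500 nM to 12000 nM.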

Compound 4, half-maximal inhibitory concentration: 5660 nM
Beside the measured number, compound 4's estimate is 1.0-fold (0.01 log units) below it; the range from low to high includes it.
By their numbers in this assay, from the lowest: compounds 3, 4, 1 and 2 (each within the scatter of the next).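

Among these compounds, the change gives a 1.1-fold lower number from compound 1 to compound 4 (0.02 log units; within the scatter) in this assay and is the first step in this set that can be read directly, with the 4-chlorophenyl to 4-methylphenyl swap as the only difference between the two structures. The earlier compounds shown here differ from one another in more than one place, so their close numbers could not show what any single group contributes, whereas this pair shows that chloro and methyl cannot be told apart by this read-out on this aromatic carbon, para to a large group. No measurement at hand explains this match, so it stands as an observation only.

The compounds shown leave open whether an amine, a carboxylic acid or a longer chain on this same carbon would move the number beyond the scatter. They also leave open whether swapping chloro for methyl here would give an equally small step if the groups elsewhere on the shared core were different.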